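The source may hold more compounds than are shown below. What is called first, only, known or untested is meant among the compounds shown, and "the series" means these compounds.

Measured compounds:
compound 1 `COc1cc2nc(N3CCC(N4CCCC(CO)C4)CC3)nc(NCc3ccc(Cl)cc3)c2cc1OC`: 140 nM
compound 2 `COc1cc2nc(N3CCC(N4CCCC(CO)C4)CC3)nc(NCCCc3ccc(Cl)cc3)c2cc1OC`: "not determined" (no result reported)

Compound 1 was tested in an in vitro functional assay on B300-19 cells for antagonist activity at C-C chemokine receptor type 4 (Mus musculus) (on this read-out lower numbers stand for stronger inhibition and higher numbers for weaker inhibition), and gives 140 nM there. For the measured compounds named here, compound 2 carries a longer link between its core and the chlorinated ring, yet it has no number in this assay: compound 2 stands nowhere on the scale, so no step from it can be measured.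

Compound 3 `COc1cc2nc(N3CCC(N4CCCC(CO)C4)CC3)nc(Nc3ccc(Cl)cc3)c2cc1OC` is the next member. Its change from compound 2 is 4-chlorophenyl in place of 3-(4-chlorophenyl)propyl on a nitrogen on an aromatic ring. The chlorinated ring is kept, but the three-carbon chain that held it away from the nitrogen is gone.

Going by the values given here, with no value for compound 2, no step can be drawn, and the size and direction of the move to compound 3 in this assay cannot be told from the numbers at hand. Among the compounds with values here, the only anchor is compound 1, whose shorter link already gave 140 nM. Compound 3 is expected to come in near 300 nM, within 60 nM to 1500 nM.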

Compound 3, half-maximal inhibitory concentration: 58 nM
For compound 3 the middle estimate is 5.2-fold (0.71 log units) above the measured one; measured number outside the range, below it.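

Putting 4-chlorophenyl in place of 4-chlorobenzyl on a nitrogen on an aromatic ring gives a 2.4-fold lower number from compound 1 to compound 3 (0.38 log units; beyond the scatter) in this assay. At this position, then, the chlorinated ring keeps its inhibition with no carbon link to the nitrogen, and in this pair the directly attached ring does modestly better than the benzyl group. Compound 2 has no number, so any step involving it cannot be read, and this conclusion rests on a single pair.

No measured evidence is available to explain the gain. From the compounds shown here alone, it remains open whether the directly attached ring needs its chlorine at all, or whether a methoxy group or a nitrile in that place would give a similar result.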